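A few compounds are considered here, and "the series" means these few. Any claim that something is new, unique, unknown or untested is made for them only; others in the source may bear on it.

Of the compounds shown here, three sharing one core have been measured in a functional assay on the whole organism with Scenedesmus acutus as the target, with a stated time of 20 h; a lower number here means a stronger inhibitor, a higher number a weaker inhibitor. Compound 1 `CCCOC(=O)c1cc(N2C(=O)C3=C(CCCC3)C2=O)ccc1Cl` gives 661 nM, compound 2 `CCCCOC(=O)c1cc(N2C(=O)C3=C(CCCC3)C2=O)ccc1Cl` gives 7760 nM, and compound 3 `CC(C)COC(=O)c1cc(N2C(=O)C3=C(CCCC3)C2=O)ccc1Cl`, which carries the isobutoxycarbonyl group, gives 15500 nM. Compound 3 therefore sits level with compound 2, as a 2.0-fold higher number from compound 2 to compound 3 (0.30 log units; within the scatter) lies within the scatter, and both sit well above compound 1, as shown by a 12-fold higher number from compound 1 to compound 2 (1.07 log units; beyond the scatter) and a 23-fold higher number from compound 1 to compound 3 (1.37 log units; beyond the scatter).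

Compound 4 `C#CCOc1cc(N2C(=O)C3=C(CCCC3)C2=O)ccc1Cl` leaves this ester set: propargyloxy in place of isobutoxycarbonyl on an aromatic carbon. This puts propargyloxy in place of isobutoxycarbonyl on an aromatic carbon, ortho to a chloro group. Going by the values given here, no measured step covers such an exchange, so the evidence is indirect. The three steps only alter the chain of the ester, yet the two large ones show that a single added methyl can move the number a long way. Among these three compounds, the lowest number belongs to compound 1 at 661 nM, and the incoming group is the smaller one. A move toward lower numbers is therefore expected, though with little certainty. The expected step is a 10-fold lower number from compound 3 to compound 4 (1.01 log units; beyond the scatter), somewhat short of the full gap to compound 1. In this assay the expected value of compound 4 is 1500 nM, with an estimated range of 150 nM to 12000 nM.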

Compound 4, half-maximal inhibitory concentration: 537 nM
Compound 4: middle estimate off by 2.8-fold (0.45 log units), on the high side; low and high end bracket the measured number.
By their numbers in this assay, from the lowest: compounds 4 and 1 (each within the scatter of the next); then compounds 2 and 3 (each within the scatter of the next).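

In this assay, the aromatic carbon ortho to a chloro group proves able to carry a group other than an ester: propargyloxy in place of isobutoxycarbonyl gives a 29-fold lower number from compound 3 to compound 4 (1.46 log units; beyond the scatter) and in place of butoxycarbonyl gives a 14-fold lower number from compound 2 to compound 4 (1.16 log units; beyond the scatter) as well, both large steps, while in place of propoxycarbonyl it gives a 1.2-fold lower number from compound 1 to compound 4 (0.09 log units; within the scatter) and so stands level. Among the esters only the propoxycarbonyl group reached this range, and the ether-linked propargyloxy group, with fewer heavy atoms and one hydrogen-bond acceptor instead of two, now reaches it too. Nothing measured here accounts for these shifts or for the match between the two groups.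

Going by these compounds, how a propoxy or an allyloxy group would read at this carbon remains open, and with it whether the triple bond of propargyloxy contributes at all. Also open, on these data alone, is whether a longer ether such as but-2-ynyloxy would raise the number as sharply as the added methyl did among the esters.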